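Working notes: cytotoxicity of compounds 1 to 3 in one series

The compounds below may be only part of what the source reports. "The series", "measured", "known", "first", "only" and "open" are said of these compounds alone.

Measured so far:
- compound 1 `N#Cc1c(-c2ccc(O)cc2)c(C#N)c(=O)n(/N=C/c2cn(-c3ccccc3)nc2-c2ccccc2)c1N`: > 200 ug/mL
- compound 2 `N#Cc1c(-c2cccc(F)c2)c(C#N)c(=O)n(/N=C/c2cn(-c3ccccc3)nc2-c2ccccc2)c1N`: > 200 ug/mL

In an ADME assay on HeLa cells (Homo sapiens) for cytotoxicity, read by MTT assay (on this read-out lower numbers stand for stronger inhibition and higher numbers for weaker inhibition), compound 1 gives > 200 ug/mL, which is a limit of the assay and not a number. In this assay compound 2 gives > 200 ug/mL, again a limit rather than a number. Among the measured compounds shown here, compound 2 therefore stands only at a limit, and the one further value shown is also a limit. For the measured compounds named here, the single step between measured compounds, a step that the two limits leave unreadable from compound 1 to compound 2, cannot be read in size or direction, since both ends sit at the limit of > 200 ug/mL in this assay, at which 2 of the 2 values shown sit.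

Compound 3 `N#Cc1c(-c2ccccc2[N+](=O)[O-])c(C#N)c(=O)n(/N=C/c2cn(-c3ccccc3)nc2-c2ccccc2)c1N` is the next analogue, with the change (2-nitrophenyl in place of 3-fluorophenyl on an aromatic carbon). Going by the values given here, no measured step bears on this change in a readable way, so there is no basis for expecting a step beyond the scatter in either direction. Given that compound 2 sits at a limit, compound 3 is expected to return 200 ug/mL, most likely again as a limit, with an estimated range of 100 ug/mL to 400 ug/mL. The expected step for compound 3 is a number no higher from compound 2 to compound 3 (the limit leaves the size open), that is, none beyond scatter.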

Compound 3, half-maximal inhibitory concentration: > 200 ug/mL
Compound 3: only a limit was reported (the forecaster's own chance of this, stated with the estimate: 80%); the middle value lies on the limit itself.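

In this assay compound 3 gives > 200 ug/mL, a limit of the assay and not a number. The steps linking compound 3 to compound 1 and compound 2 therefore cannot be read in size or direction: the limit of > 200 ug/mL in this assay, at which 3 of the 3 values shown sit.

The compounds shown leave open whether 4-hydroxyphenyl, 3-fluorophenyl and 2-nitrophenyl differ at all in this assay.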